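Triazolopyridine aminopyrazoles: benzyl replaces 4-fluorophenyl

This account rests on a few compounds, and the source may have more. Where it says the series, first, only, none or still open, it means among the compounds named here.

Measured compounds:
compound 1 `Nc1cc(Cc2ccn(Cc3cccc(-c4ccccc4)c3)n2)c2nn[nH]c2n1` — in an assay on isolated protein for inhibition of Myeloperoxidase (Homo sapiens), with a stated time of 10 min (on this read-out lower numbers stand for stronger inhibition and higher numbers for weaker inhibition), compound 1 gives 55 nM
compound 2 `Nc1cc(Cc2ccn(-c3ccc(F)cc3)n2)c2nn[nH]c2n1` — in this assay compound 2 gives 53 nM

Compound 2 and compound 1 give values in this assay that lie within the usual scatter of each other, so the two cannot be told apart on the numbers shown. Compound 3 `Nc1cc(Cc2ccn(Cc3ccccc3)n2)c2nn[nH]c2n1` has not been measured. It differs from compound 2 in one place: benzyl in place of 4-fluorophenyl on an aromatic nitrogen. For the measured compounds named here, no measured pair shows this particular change, so its effect can only be judged from the two neighbours. Since compound 1 also carries a benzyl-type group on that nitrogen and gives 55 nM, a benzyl group appears compatible with this level of inhibition. Compound 3 is therefore expected to show a step of a 1.4-fold higher number from compound 2 to compound 3 (0.15 log units; within the scatter) that stays within the scatter or is at most a modest weakening. The estimated value for compound 3 is 75 nM, with a range from 25 nM to 220 nM.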

Compound 3, half-maximal inhibitory concentration: 120 nM
For compound 3 the middle estimate is 1.6-fold (0.20 log units) below the measured one, within the range that was stated.
By their numbers in this assay, from the lowest: compounds 2 and 1 (each within the scatter of the next); then compound 3.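

In this assay, this nitrogen of the five-membered ring proves sensitive to a change that leaves the ring count untouched: benzyl in place of 4-fluorophenyl gives a 2.3-fold higher number from compound 2 to compound 3 (0.35 log units; beyond the scatter), a modest loss that the near-equal values of the two earlier compounds could not reveal. Benzyl alone also does not carry the inhibition seen with the larger group, since hydrogen in place of phenyl on the benzyl ring gives a 2.2-fold higher number from compound 1 to compound 3 (0.34 log units; beyond the scatter), so that outer phenyl contributes in this comparison. Nothing among the data shown gives a reason for either step.

Still open, going by these compounds, is how an unsubstituted phenyl on that nitrogen would compare with 4-fluorophenyl. Also open, on these data alone, is whether a longer chain such as phenethyl, or an amine or a carboxylic acid on the benzyl ring, would recover the lost inhibition.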